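A few compounds are considered here, and "the series" means these few. Any claim that something is new, unique, unknown or untested is made for them only; others in the source may bear on it.

Measured so far in a functional assay on IMR-32 cells with melanin-concentrating hormone receptor 1 (Homo sapiens) as the target, read by fluorescence; on this read-out higher numbers stand for weaker inhibition and lower numbers for stronger inhibition:

Compound 1 `COc1cccc(CNCC(C)Oc2cccc3ccc(N)nc23)c1` gives 600 nM
Compound 2 `CC(CNCc1ccoc1)Oc1cccc2ccc(N)nc12` gives 100 nM

Within the data shown here, of the two compounds measured, compound 2 stands lowest; the only other number, that of compound 1, lies a 6.0-fold lower number from compound 1 to compound 2 (0.78 log units; beyond the scatter) away, so the gap between them is beyond the scatter. Among the measured compounds shown here, that single step exchanged one aromatic group for another on the same saturated chain carbon bound to an amine nitrogen, and it is the only step recorded.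

Compound 3 `CC(CNCc1ccsc1)Oc1cccc2ccc(N)nc12` has not yet been measured. It differs from compound 2 in one place: thiophen-3-yl in place of furan-3-yl on a saturated chain carbon bound to an amine nitrogen. For the measured compounds named here, no measured step covers this particular exchange. Going by the values given here, the one step known, from compound 1 to compound 2, concerned a different replacement at the same place, and it does not tell how a five-membered ring with one oxygen compares with a five-membered ring with one sulfur. With nothing to push the expectation either way, the number for compound 3 is expected to stay close to that of compound 2, with no step beyond the scatter.

The step from compound 2 to compound 3 is expected to be no change at the digits printed from compound 2 to compound 3 (within the scatter) in this assay. Compound 3 is therefore estimated at 100 nM, within a range from 40 nM to 250 nM.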

Compound 3, half-maximal inhibitory concentration: 150 nM
Beside the measured number, compound 3's estimate is 1.5-fold (0.18 log units) below it; the range from low to high includes it.
By their numbers in this assay, from the lowest: compounds 2 and 3 (each within the scatter of the next); then compound 1.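

In this assay, putting thiophen-3-yl in place of furan-3-yl on the saturated chain carbon bound to an amine nitrogen gives a 1.5-fold higher number from compound 2 to compound 3 (0.18 log units; within the scatter) and so the two five-membered aromatic rings, one with oxygen and one with sulfur, cannot be told apart on this read-out. The earlier step had set only furan-3-yl against 3-methoxyphenyl, whereas a second five-membered ring now gives a 4.0-fold lower number from compound 1 to compound 3 (0.60 log units; beyond the scatter) and so the lower number relative to compound 1 is not confined to furan-3-yl. Nothing measured here explains why the oxygen and sulfur rings read alike or why both differ from 3-methoxyphenyl.

The compounds shown leave open whether the difference from compound 1 goes with the methoxy group or with the six-membered ring itself, a question that an unsubstituted phenyl at the same place would address. They also leave open whether the same place accepts a thiophen-2-yl or furan-2-yl group, a pyridin-3-yl ring, or a saturated ring such as cyclohexyl.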